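A Cyclohexyl Amide in Place of a Chloroaniline

The source may hold more compounds than are shown below. What is called first, only, known or untested is meant among the compounds shown, and "the series" means these compounds.

Of the compounds shown here, two sharing one core have been measured in an assay on blood for inhibition of Indoleamine 2,3-dioxygenase 1 (Homo sapiens), read by mass spectrometry, with stated times of 4 h and 18 h; on this read-out higher numbers stand for weaker inhibition and lower numbers for stronger inhibition. Compound 2, `C[C@@H](CNc1ccc(Cl)cc1)[C@H]1CC[C@@H](c2ccnc3ccc(F)cc32)CC1`, gives 44 nM in this assay. Compound 1, `COc1ncc(NC(=O)[C@H](C)[C@H]2CC[C@@H](c3ccnc4ccc(F)cc43)CC2)cn1`, gives 80 nM in this assay. These two numbers sit within the usual scatter of each other, so no difference between compound 1 and compound 2 can be claimed from them, and compound 2 is simply one of two similar readings.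

The step under consideration leads from compound 2 to compound 3, `C[C@@H](NC(=O)C1CCCCC1)[C@H]1CC[C@@H](c2ccnc3ccc(F)cc32)CC1`. The change is (cyclohexylcarbonyl)amino in place of ((4-chlorophenyl)amino)methyl on a saturated chain carbon bound to a saturated chain carbon and a saturated ring carbon. Both the group that leaves and the group that enters carry one hydrogen-bond donor and one hydrogen-bond acceptor, but the aromatic ring with its chlorine gives way to a saturated ring joined through a carbonyl.

Within the data shown here, no measured pair shows a change of this kind, so the size of the step is open. A modest rise in the number, toward weaker inhibition, is expected, with a change of a 3.4-fold higher number from compound 2 to compound 3 (0.53 log units; beyond the scatter) from compound 2 to compound 3 as the estimate. Compound 3 is expected to give about 150 nM in this assay, somewhere between 40 nM and 600 nM.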

Compound 3, half-maximal inhibitory concentration: 294 nM
Beside the measured number, compound 3's estimate is 2.0-fold (0.29 log units) below it; low and high end bracket the measured number.
By their numbers in this assay, from the lowest: compounds 2 and 1 (each within the scatter of the next); then compound 3.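

Within this assay, placing (cyclohexylcarbonyl)amino on this saturated chain carbon in place of ((4-chlorophenyl)amino)methyl gives a 6.7-fold higher number from compound 2 to compound 3 (0.82 log units; beyond the scatter), so inhibition is weaker with the entering group. This position therefore does not accept every group of similar size: the two groups have the same number of heavy atoms, hydrogen-bond donors and hydrogen-bond acceptors, and neither carries a net charge, yet the reading still shifts beyond the usual scatter. No independent measurement here bears on why the number rises.

The step changes several features at once, since the aromatic ring becomes a saturated ring, the chlorine is replaced by a carbonyl oxygen elsewhere in the group, and the way the ring is joined to the chain also differs, so the compounds shown cannot assign the rise to any one of these. Two groups would help to separate these features: ((cyclohexyl)amino)methyl, which keeps the link of compound 2 with the ring of compound 3, and ((4-chlorophenyl)carbonyl)amino, which keeps the link of compound 3 with the ring of compound 2.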